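Methyl for Methoxy on Two Different Cores

This account rests on a few compounds, and the source may have more. Where it says the series, first, only, none or still open, it means among the compounds named here.

Three compounds have been measured in a functional assay on MCF7 cells (Homo sapiens) for cytotoxicity, read by sulforhodamine B assay, with a stated time of 72 h; a higher number here means a weaker inhibitor, a lower number a stronger inhibitor:

compound 1, `CC(=O)c1nn(-c2ccc(C)cc2)/c(=N/c2nc(-c3c(C)n(C)n(-c4ccccc4)c3=O)cs2)s1`: 56800 nM
compound 2, `COc1ccc(-n2nc(C(C)=O)s/c2=N\c2nc(-c3c(C)n(C)n(-c4ccccc4)c3=O)cs2)cc1`: 64500 nM
compound 3, `COc1ccc(/C=C2\S/C(=N\c3nc(-c4c(C)n(C)n(-c5ccccc5)c4=O)cs3)N(c3ccccc3)C2=O)cc1`: 26100 nM

Compounds 1 and 2 share one core, and compound 1 differs from compound 2 by methyl in place of methoxy on an aromatic carbon. That change gave a 1.1-fold lower number from compound 2 to compound 1 (0.06 log units; within the scatter). Compound 3 has a different core; how it differs from compound 2 is not broken down here. In this assay compound 3 stands lowest of the three, with compound 1 a step above it that lies beyond the scatter, and compound 2 a little further still.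

Compound 4, `Cc1ccc(/C=C2\S/C(=N\c3nc(-c4c(C)n(C)n(-c5ccccc5)c4=O)cs3)N(c3ccccc3)C2=O)cc1`, has not yet been measured. It differs from compound 3 by methyl in place of methoxy on an aromatic carbon. The place of this change is described in the same words as for the change from compound 2 to compound 1, so it is the same change, made this time on the core of compound 3. On that core the step is expected to be small, close to what the same change gave in a 1.1-fold lower number from compound 2 to compound 1 (0.06 log units; within the scatter). Compound 4 is therefore expected to sit close to compound 3, a 1.0-fold lower number from compound 3 to compound 4 (0.02 log units; within the scatter). Compound 4 is estimated at 25000 nM, with a likely span from 12000 nM to 50000 nM.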

Compound 4, half-maximal inhibitory concentration: > 100000 nM
Compound 4: a limit, no number (the forecaster's own chance of this, stated with the estimate: 5%); middle value at least 4.0-fold (0.60 log units) away from the limit.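

In this assay compound 4 gives > 100000 nM, which is a limit of the assay and not a number. Among these compounds, on the core of compound 3, methyl in place of methoxy gives an at least 3.8-fold higher number from compound 3 to compound 4 (0.58 log units; beyond the scatter), so the result of this change does not carry over in size from one core to the other: the same change on two cores in this assay, a 1.1-fold lower number (0.06 log units; within the scatter) from compound 2 to compound 1 and an at least 3.8-fold higher number (0.58 log units; beyond the scatter) from compound 3 to compound 4, at least 4.3-fold (0.63 log units) apart, beyond the scatter of two such steps With only one pair of compounds on each core, this shows that the outcome of the change depends on the core in these four compounds, but it does not show why, what the exact size of the step on the core of compound 3 is, or what would happen on any further core.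

The compounds shown leave open how other groups would behave in the same place on the core of compound 3, such as a chlorine atom, a hydroxyl or an amine. They also leave open whether a longer chain, such as ethoxy, would separate the two cores in the same way.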